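A few compounds are considered here, and "the series" means these few. Any claim that something is new, unique, unknown or untested is made for them only; others in the source may bear on it.

Measured in an assay on cell membranes from Cerebral cortex for displacement of a labelled ligand from Sigma non-opioid intracellular receptor 1 (Cavia porcellus), read by scintillation counting, with a stated time of 120 min; a lower number here means a stronger inhibitor, a higher number a weaker inhibitor:
- compound 1, `CN(CCCCN1C(=O)OC[C@H]1c1ccccc1)Cc1ccc(Cl)cc1`: 2.9 nM
- compound 2, `CN(CCCCN1C(=O)CSc2ccccc21)Cc1ccccc1`: 5 nM
- compound 3, `CN(CCCCn1nc(-c2ccccc2)oc1=O)Cc1ccccc1`: 5.2 nM

Three compounds with the same basic amine side chain carry different cyclic groups at the chain end. In this assay compound 1 gives 2.9 nM, compound 2 gives 5 nM and compound 3 gives 5.2 nM. Compound 1 sits at the low end of the three numbers, but compound 2 and compound 3 each lie within the scatter of it, so the three values are not separated by this assay.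

The next compound, compound 4, `CN(CCCCN1C(=O)OC[C@@H]1c1ccccc1)Cc1ccc(Cl)cc1`, is the mirror form of compound 1 at its single stereocentre: the two compounds have the same atoms and bonds and differ only in configuration as drawn: 1 of 1 stereo elements differ; a stereocentre at a saturated ring carbon is drawn R in compound 1 and S in compound 4. Among the measured compounds shown here, no pair among the measured compounds differs only in configuration, so there is no measured step to lean on for the size of such a change. In the absence of such a reference, the step from compound 1 to compound 4 is estimated as a modest loss, of the order of the scatter or somewhat beyond it, a 1.7-fold higher number from compound 1 to compound 4 (0.24 log units; within the scatter), with the possibility of no change at all kept open.

Compound 4 is therefore expected to give about 5 nM in this assay, with a range from 1.5 nM to 20 nM.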

Compound 4, inhibition constant: 9.3 nM
Compound 4: the middle estimate sits 1.9-fold (0.27 log units) below what was measured; the measured number falls inside the stated range.
By their numbers in this assay, from the lowest: compounds 1, 2, 3 and 4 (each within the scatter of the next, the first and the last beyond it).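

In this assay, among the compounds shown here, the stereocentre at the saturated ring carbon is the first place where a single change can be read: going from R to S gives a 3.2-fold higher number from compound 1 to compound 4 (0.51 log units; beyond the scatter). The step belongs to the configuration at this carbon alone, because nothing else separates the pair: the fact that compounds 1 and 4 differ only in the configuration as drawn. For the compounds shown here, the configuration therefore moves the number by a modest but readable amount without abolishing activity, as compound 4 still gives 9.3 nM, whereas the earlier compounds differed in more than one place and gave no step to read.

From the compounds shown here alone, this single pair gives one step in one setting, so it remains open whether the same direction and size would hold with a longer chain between the amine and the ring or with fluorine in place of the chlorine. Going by these compounds, it also remains open whether a substituent on the phenyl group at the stereocentre, such as methoxy, would widen or narrow the gap between the two configurations.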